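The source may hold more compounds than are shown below. What is called first, only, known or untested is meant among the compounds shown, and "the series" means these compounds.

The series shares one core, shown in compound 1 `C=CC1=C(C(=O)Nc2cccc(C)c2)C(c2ccc(F)cc2)OC1`, compound 2 `C=CC1=C(C(=O)NCCC)C(c2ccc(F)cc2)OC1` and compound 3 `C=CC1=C(C(=O)NCc2ccccc2)C(c2ccc(OC)cc2)OC1`. All three were examined in a functional assay on HeLa cells (Homo sapiens) for cytotoxicity, read by MTT assay, with a stated time of 24 h; on this read-out lower numbers stand for stronger inhibition and higher numbers for weaker inhibition. For compound 1 the result is recorded without a number, as "not active" (no number reported). Compound 2 reaches only a limit of the assay, > 100000 nM. Compound 3 likewise gives only a limit of the assay, > 100000 nM. Among the numbers shown, compound 3 therefore stands at the same point as compound 2, while the entry for compound 1 carries no number at all; nothing in this set separates one compound from another. Compound 4 `C=CC1=C(C(=O)NCc2ccccc2)C(c2ccc(F)cc2)OC1` has not yet been measured in this assay. It differs from compound 3 by fluoro in place of methoxy on an aromatic carbon. Within the data shown here, no step between two measured compounds is available, so the size of this step cannot be read from a neighbouring pair. A step that the limit leaves unreadable from compound 3 to compound 4 is expected, nothing beyond the scatter, given that compound 3 already sits at the limit of > 100000 nM in this assay, at which 2 of the 3 values shown sit. Compound 4 is thus estimated at 150000 nM, within a range from 30000 nM to 1000000 nM, and most probably the assay will again report only a limit.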

Compound 4, half-maximal inhibitory concentration: > 100000 nM
Compound 4 ended at the assay's limit; the forecaster's own chance of this, stated with the estimate: 85%; the middle value lies beyond the limit too.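

Compound 4, like compound 3 and compound 2, gives only a limit of the assay, so no size can be read for the step from compound 3 to compound 4 or from compound 2 to compound 4. The set stays at one point: the limit of > 100000 nM in this assay, at which 3 of the 4 values shown sit.

The compounds shown leave open whether either change alters cytotoxicity at all.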